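The source may hold more compounds than are shown below. What is called first, only, known or untested is meant among the compounds shown, and "the series" means these compounds.

Going by the values given here, compound 1 `Clc1cccc(C2CC(c3ccc4c(c3)OCCO4)=NN2c2ccccc2)c1` holds the lowest number of the two measured so far: in a functional assay on WM 266-4 cells (Homo sapiens) for antiproliferative activity, read by MTT assay, with a stated time of 24 h (a lower number here means a stronger inhibitor of growth, a higher number a weaker inhibitor of growth), compound 1 gives 1750 nM, while compound 2 `Fc1ccccc1C1CC(c2ccc3c(c2)OCCO3)=NN1c1ccccc1` gives 9120 nM. Among the compounds with values here, the one step between them, a 5.2-fold higher number from compound 1 to compound 2 (0.72 log units; beyond the scatter), arises from exchanging the aryl group on the saturated ring carbon. Compound 3 `COc1ccc(C2CC(c3ccc4c(c3)OCCO4)=NN2c2ccccc2)cc1` differs from compound 1 in that same place: 4-methoxyphenyl in place of 3-chlorophenyl on a saturated ring carbon. Within the data shown here, only that single step bears on the change, and it shows that replacing this aryl group can shift the number beyond the scatter, though it involves a different group, and the 4-methoxyphenyl group has no direct precedent here. Among the measured compounds shown here, a modest move toward a higher number is therefore expected, smaller than the one seen for compound 2 because that step, a 5.2-fold higher number from compound 1 to compound 2 (0.72 log units; beyond the scatter), is the only guide, giving a 1.7-fold higher number from compound 1 to compound 3 (0.23 log units; within the scatter). Compound 3 is estimated at 3000 nM, with a range from 1000 nM to 9000 nM.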

Compound 3, concentration for 50% growth inhibition: > 100000 nM
Compound 3 ended at the assay's limit; the forecaster's own chance of this, stated with the estimate: 5%; middle value at least 33-fold (1.52 log units) away from the limit.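

In this assay the entry for compound 3, > 100000 nM, is a limit of the assay and not a number: the limit of > 100000 nM in this assay, at which 1 of the 3 values shown sits.

Even read as a limit, the change matters more than the earlier step showed, since 4-methoxyphenyl in place of 3-chlorophenyl gives an at least 57-fold higher number from compound 1 to compound 3 (1.75 log units; beyond the scatter), and 4-methoxyphenyl in place of 2-fluorophenyl gives an at least 10-fold higher number from compound 2 to compound 3 (1.04 log units; beyond the scatter). The aryl group on this saturated ring carbon can therefore do more than produce a modest shift, and the shared core alone does not secure a value inside the measured range.

The compounds shown leave open how far beyond the limit compound 3 lies. They also cannot separate the methoxy group from its ring position, which 3-methoxyphenyl and 4-chlorophenyl groups at this carbon would address.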